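The source may report more compounds than this note shows. Statements on the series, on what has been measured and on what is new or still open speak of the compounds shown alone.

Two analogues of the shared core of compound 1 `CNC(=O)c1cc(Oc2ccc(/C=C/c3ccncc3)cc2)ccn1` have been run in a functional assay on A549 cells (Homo sapiens) for antiproliferative activity, read by CCK-8 assay, with a stated time of 48 h; a higher number here means a weaker inhibitor, a lower number a stronger inhibitor. Compound 1 gives 13200 nM. Compound 2 `O=C(NCc1ccc(F)cc1)c1cc(Oc2ccc(/C=C/c3ccncc3)cc2)ccn1`, with 4-fluorophenyl in place of hydrogen on the saturated chain carbon bound to the amide-type nitrogen, gives 18200 nM in this assay; the step of a 1.4-fold higher number from compound 1 to compound 2 (0.14 log units; within the scatter) leaves the two compounds indistinguishable on these numbers, so compound 2 stands level with compound 1, the only other point measured.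

Compound 3 `O=C(NC1CC1)c1cc(Oc2ccc(/C=C/c3ccncc3)cc2)ccn1` awaits measurement. It differs from compound 2 by cyclopropyl in place of 4-fluorobenzyl on an amide-type nitrogen. For the measured compounds named here, the one measured step that bears on this position, a 1.4-fold higher number from compound 1 to compound 2 (0.14 log units; within the scatter), shows the amide-type nitrogen tolerating a large change with no shift beyond the scatter, so a step of a 1.3-fold lower number from compound 2 to compound 3 (0.11 log units; within the scatter) of no more than the scatter is expected in this assay, in neither direction in particular. Compound 3 is therefore estimated at 14000 nM, within 6000 nM to 35000 nM.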

Compound 3, half-maximal inhibitory concentration: 35500 nM
Beside the measured number, compound 3's estimate is 2.5-fold (0.40 log units) below it; measured number outside the range, above it.
By their numbers in this assay, from the lowest: compounds 1, 2 and 3 (each within the scatter of the next, the first and the last beyond it).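

In this assay, for the compounds shown here, the step of a 2.7-fold higher number from compound 1 to compound 3 (0.43 log units; beyond the scatter) is the first on this amide-type nitrogen to lie beyond the scatter, so the position is not wholly indifferent to its substituent, although the shift is modest. The step of a 2.0-fold higher number from compound 2 to compound 3 (0.29 log units; within the scatter) remains within the scatter, so cyclopropyl and 4-fluorobenzyl cannot be ordered on this nitrogen, and only methyl and cyclopropyl are separated. No supporting evidence is available to account for that separation.

Still open, on these data alone, is whether any group on this nitrogen lowers the number beyond the scatter relative to methyl, for example an unsubstituted benzyl, a longer alkyl chain or a chain ending in an amine. The three compounds also leave untested whether replacing the amide hydrogen with a second methyl changes the reading.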